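Methylsulfonyl in Place of Chloro on the Quinone Core

The source may report more compounds than this note shows. Statements on the series, on what has been measured and on what is new or still open speak of the compounds shown alone.

Compound 1, `CNC1=C(Cl)C(=O)c2ncccc2C1=O`: 78900 nM
Compound 2, `NC1=C(Cl)C(=O)c2ncccc2C1=O`: > 200000 nM

In a functional assay on cells (Neutrophil, Homo sapiens) for inhibition, read by WST assay, with a stated time of 20 min (on this read-out lower numbers stand for stronger inhibition and higher numbers for weaker inhibition), compound 1 gives 78900 nM. For compound 2 this assay reports only a limit, > 200000 nM, as noted in the limit of > 200000 nM in this assay, at which 1 of the 2 values shown sits, so compound 2 stands at that limit without a number. Among the measured compounds shown here, the single measured step, an at least 2.5-fold higher number from compound 1 to compound 2 (0.40 log units; beyond the scatter), concerns the amine nitrogen alone. Compound 3, `CS(=O)(=O)C1=C(N)C(=O)c2cccnc2C1=O`, differs from compound 2 by methylsulfonyl in place of chloro on a double-bonded ring carbon. No measured step bears on this exchange, so neither direction nor size can be drawn from the shown steps. Compound 3 is therefore expected to give 150000 nM, within 30000 nM to 600000 nM. The expected step is an at least 1.3-fold lower number from compound 2 to compound 3 (0.12 log units; that floor lies within the scatter), with a real chance that only a limit is again reported.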

Compound 3, half-maximal inhibitory concentration: > 200000 nM
Compound 3: a limit, no number; the forecaster's own chance of this, stated with the estimate: 55%; at least 1.3-fold (0.12 log units) between middle value and limit.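

In this assay compound 3 gives > 200000 nM as a limit and not a number. Compound 2 also stands at a limit, so no step can be read between compound 2 and compound 3. Going by these compounds, whether methylsulfonyl in place of chloro on a double-bonded ring carbon strengthens or weakens inhibition stays open.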